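This account rests on a few compounds, and the source may have more. Where it says the series, first, only, none or still open, it means among the compounds named here.

Measured compounds in a functional assay on WHCO1 cells (Homo sapiens) for antiproliferative activity, read by MTT assay, with a stated time of 48 h; a higher number here means a weaker inhibitor, a lower number a stronger inhibitor:
- compound 1, `C=CCSSC=CC[S+]([O-])Cc1ccccc1`: 8900 nM
- compound 2, `C=CCSSC=CC[S+]([O-])Cc1ccc(OC)cc1`: 7400 nM
- compound 3, `CCCSS/C=C\C[S+]([O-])CCC`: 18000 nM

Compound 2 gives the lowest number of the three in this assay. Its nearest neighbour is compound 1: the step of a 1.2-fold lower number from compound 1 to compound 2 (0.08 log units; within the scatter) lies within the scatter, so the two cannot be ordered. Among the compounds with values here, compound 3 stands furthest from compound 2, with a gap beyond the scatter, but the two differ in more than one place and no single step between them is known.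

Compound 4, `COc1ccc(C[S+]([O-])CC=CSSCc2ccccc2)cc1`, is not yet measured. It differs from compound 2 as follows: phenyl in place of vinyl on a saturated chain carbon bound to a sulfur. Cut one bond further out, the change reads allyl to benzyl. Within the data shown here, no measured step among the three compounds changes this part of the molecule; the only single-change step known, from compound 1 to compound 2, touches the aromatic carbon instead and is within the scatter. Among the measured compounds shown here, there is thus no precedent for the size of the step in this assay, and the expectation is for no step beyond the scatter: compound 4 is estimated to come out at roughly the level of compound 2, a 1.1-fold lower number from compound 2 to compound 4 (0.06 log units; within the scatter), giving an expected value of 6500 nM with a range of 3000 nM to 14000 nM.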

Compound 4, half-maximal inhibitory concentration: 3100 nM
Compound 4: the middle estimate sits 2.1-fold (0.32 log units) above what was measured; the range from low to high includes it.
By their numbers in this assay, from the lowest: compound 4; then compounds 2 and 1 (each within the scatter of the next); then compound 3.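

In this assay, within the data shown here, the change of allyl to benzyl on a saturated chain carbon bound to a sulfur gives a 2.4-fold lower number from compound 2 to compound 4 (0.38 log units; beyond the scatter), a modest step and the first single change to pass beyond the scatter. Among these compounds, the only other single-change step, at the aromatic carbon, stays within the scatter at a 1.2-fold lower number from compound 1 to compound 2 (0.08 log units; within the scatter), so this chain position is the one so far where a single change moves the number, and a phenyl is accepted there in place of a vinyl without any rise in the number. No available evidence bears on the reason for this step.

One pair on one background cannot show whether the step carries over to the core of compound 1, which lacks the methoxy. Also open, on these data alone, is how a longer chain such as hexyl, or a benzyl carrying an amine or a carboxylic acid, would read at this place.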